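Swapping the group on the amide nitrogen of a shared core

This account rests on a few compounds, and the source may have more. Where it says the series, first, only, none or still open, it means among the compounds named here.

Compound 2 `CCOc1nc2cccc(C(=O)Nc3ccc(OC)cc3)c2n1Cc1ccc(-c2ccccc2-c2nnn[nH]2)cc1` and compound 1 `CCOc1nc2cccc(C(=O)NCCCN(C)C)c2n1Cc1ccc(-c2ccccc2-c2nnn[nH]2)cc1` share one core and differ only at an amide-type nitrogen. In an assay on isolated protein for inhibition of NEDD8-activating enzyme E1 regulatory subunit (Homo sapiens), read by Western blot, with stated times of 10 min and 30 min, tested at 25 uM (on this read-out higher numbers stand for more inhibition at the one concentration tested (going by the name of the read-out) and lower numbers for less inhibition), compound 1 gives 29.5%, and compound 2 gives 25.8%. Compound 2 thus stands as the lower of the two numbers, yet the step of a number 3.7 percentage points lower from compound 1 to compound 2 (within the scatter) is within the scatter, so no real order between them can be claimed. Compound 3 `CCOc1nc2cccc(C(=O)NCc3ccccc3)c2n1Cc1ccc(-c2ccccc2-c2nnn[nH]2)cc1` has not been measured. Within the data shown here, it differs from compound 2 as follows: benzyl in place of 4-methoxyphenyl on an amide-type nitrogen The only measured step that bears on this change is a number 3.7 percentage points lower from compound 1 to compound 2 (within the scatter), which also replaced the group on the amide-type nitrogen and left the read-out essentially unchanged. The new change, benzyl in place of 4-methoxyphenyl, is therefore expected to move this assay by no more than the scatter, in no clear direction. Compound 3 is estimated at 27%, within a range from 15% to 40%, which amounts to an expected step of a number 1.2 percentage points higher from compound 2 to compound 3 (within the scatter).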

Compound 3, a percentage reported as inhibition, at one concentration (the size of the read-out at that concentration, not a potency): 48.9%
Compound 3: the middle estimate sits 21.9 percentage points below what was measured; the whole stated range lies below it.
By their numbers in this assay, from the lowest: compounds 2 and 1 (each within the scatter of the next); then compound 3.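

The group on the amide nitrogen does matter in this assay: the earlier swap at this nitrogen gave no step beyond the scatter, but benzyl in place of 4-methoxyphenyl gives a number 23.1 percentage points higher from compound 2 to compound 3 (beyond the scatter) and so shows that this position can change the read-out. Benzyl also stands apart from the 3-(dimethylamino)propyl group, with a number 19.4 percentage points higher from compound 1 to compound 3 (beyond the scatter), which makes compound 3 the highest of the three at the one concentration tested. No measurement here accounts for this gain.

This swap removes the methoxy group and puts a saturated carbon on the nitrogen in a single change, so a plain phenyl group on the amide nitrogen would be needed to tell those two parts apart. Also open, on these data alone, is whether a longer chain, such as 2-phenylethyl, would keep the gain.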